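A Cyclic Amine Replaces the Open Chain

The compounds below may be only part of what the source reports. "The series", "measured", "known", "first", "only" and "open" are said of these compounds alone.

Compound 1 `C=CCN(CCC)Cc1c(C(F)(F)F)nc2n(-c3c(C)cc(C)cc3C)c(Cl)cn12`: 4.5 nM
Compound 2 `CCCN(Cc1ccc([N+](=O)[O-])cc1)Cc1c(C(F)(F)F)nc2n(-c3c(C)cc(C)cc3C)c(Cl)cn12`: 150 nM
Compound 3 `CCCN(Cc1ccc(F)cc1)Cc1c(C(F)(F)F)nc2n(-c3c(C)cc(C)cc3C)c(Cl)cn12`: 350 nM

The three measured compounds share one core and differ only in the amine carried on the saturated chain carbon bound to that core. In an assay on cells for displacement of a labelled ligand from corticotropin-releasing factor receptor 1 (Homo sapiens), with a stated time of 100 min (a higher number here means a weaker inhibitor, a lower number a stronger inhibitor), compound 1 gives the lowest of the three numbers, with compound 2 nearest to it and compound 3 furthest away. Both neighbours carry an aryl group where compound 1 carries a vinyl group, and both steps are large: a 33-fold higher number from compound 1 to compound 2 (1.52 log units; beyond the scatter) and a 78-fold higher number from compound 1 to compound 3 (1.89 log units; beyond the scatter). Between the two aryl compounds the gap is modest, a 2.3-fold higher number from compound 2 to compound 3 (0.37 log units; beyond the scatter).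

Compound 4 `Cc1cc(C)c(-n2c(Cl)cn3c(CN4CCCC4c4ccccc4)c(C(F)(F)F)nc23)c(C)c1` is not yet measured. Its change from compound 1 is 2-phenylpyrrolidin-1-yl in place of allyl(propyl)amino on a saturated chain carbon bound to an aromatic carbon. This is not the same change as in the measured steps, since the whole open-chain amine leaves and a ring amine bearing a phenyl enters; yet the one lesson the data give is that bringing an aromatic ring into this amine weakened binding in this assay by a large margin in both measured cases. A large step in the same direction is therefore expected, a 27-fold higher number from compound 1 to compound 4 (1.43 log units; beyond the scatter), and compound 4 is estimated at 120 nM, within the range 20 nM to 700 nM.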

Compound 4, inhibition constant: > 7000 nM
Compound 4 was reported as a limit; the forecaster's own chance of this, stated with the estimate: 5%; middle value at least 58-fold (1.76 log units) away from the limit.
By their numbers in this assay, from the lowest: compound 1; then compound 2; then compound 3. At a limit, above all of these: compound 4.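

In this assay compound 4 is reported only as a limit, > 7000 nM, and not as a number. Even so, the step is an at least 1500-fold higher number from compound 1 to compound 4 (3.19 log units; beyond the scatter), so 2-phenylpyrrolidin-1-yl in place of allyl(propyl)amino on this saturated chain carbon costs more than either step that kept an open-chain amine and added an aryl group, a 33-fold higher number from compound 1 to compound 2 (1.52 log units; beyond the scatter) and a 78-fold higher number from compound 1 to compound 3 (1.89 log units; beyond the scatter). Among these compounds, the change does not alter the counts of hydrogen-bond donors and acceptors or the net charge, so these counts do not separate the entering amine from the one that leaves, and the earlier compounds gave no sign that an amine at this place could fall this far.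

The compounds shown leave open how much of this step belongs to the ring and how much to its phenyl group, since the two enter together and the amine of compound 4 has no counterpart without the phenyl, such as an unsubstituted pyrrolidin-1-yl or a piperidin-1-yl. They also leave open whether a small alkyl group such as methyl in place of the phenyl on the pyrrolidine ring would bring the number back towards that of compound 1.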